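Phenylsulfonyl replaces cyclohexenylmethyl on the shared pyrimidine-ester core

This account rests on a few compounds, and the source may have more. Where it says the series, first, only, none or still open, it means among the compounds named here.

Compound 1 `CCOC(=O)c1cnc(C2CC2)nc1NN1C(=O)C=C(C)C1=O`: 1000 nM
Compound 2 `CCOC(=O)c1cnc(CC2=CCCCC2)nc1NN1C(=O)C=C(C)C1=O`: 2000 nM

For the measured compounds named here, in a functional assay on Jurkat cells for inhibition of nuclear factor NF-kappa-B complex (Homo sapiens) (a lower number here means a stronger inhibitor, a higher number a weaker inhibitor), compound 1 gives 1000 nM and compound 2 gives 2000 nM; the one step measured, a 2.0-fold higher number from compound 1 to compound 2 (0.30 log units; within the scatter), lies within the scatter, so the two numbers cannot be ordered. Compound 3 `CCOC(=O)c1cnc(S(=O)(=O)c2ccccc2)nc1NN1C(=O)C=C(C)C1=O` differs from compound 2 by phenylsulfonyl in place of (cyclohex-1-en-1-yl)methyl on an aromatic carbon. Going by the values given here, the only step that bears on this position is that from compound 1 to compound 2, which was within the scatter, so no step beyond the scatter is expected in this assay, and compound 3 is estimated at 2000 nM, range 500 nM to 8000 nM, a step of no change at the digits printed from compound 2 to compound 3 (within the scatter).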

Compound 3, half-maximal inhibitory concentration: 10000 nM
Compound 3: the middle estimate sits 5.0-fold (0.70 log units) below what was measured; measured number above the stated range.
By their numbers in this assay, from the lowest: compounds 1 and 2 (each within the scatter of the next); then compound 3.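

In this assay, this position proves able to move the number beyond the scatter: phenylsulfonyl in place of (cyclohex-1-en-1-yl)methyl gives a 5.0-fold higher number from compound 2 to compound 3 (0.70 log units; beyond the scatter), and in place of cyclopropyl it gives a 10-fold higher number from compound 1 to compound 3 (1.00 log units; beyond the scatter), whereas the earlier change at this carbon could not be read as a difference. No measurement here accounts for these steps.

The compounds shown leave open whether the sulfonyl link or the phenyl ring carries the change. A methylsulfonyl group or a directly attached phenyl at this carbon would separate the two, and an amine there would test a different kind of group.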